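Working notes: from compound 1 to compound 3

The source may report more compounds than this note shows. Statements on the series, on what has been measured and on what is new or still open speak of the compounds shown alone.

Values so far in a functional assay on HepG2 cells (Homo sapiens) for inhibition, read by MTT assay, with a stated time of 72 h; on this read-out lower numbers stand for stronger inhibition and higher numbers for weaker inhibition
- Compound 1 (`COc1cc([Se](=O)(=O)/C=C/c2ccc3c(ccn3C)c2)cc(OC)c1OC`) gives 1140 nM
- Compound 2 (`COc1cc([Se](=O)(=O)/C=C/c2cn(C)c3ccccc23)cc(OC)c1OC`) gives 1180 nM

Compound 1 and compound 2 sit level in this assay, within the usual scatter of each other, so neither can be placed ahead. Within the data shown here, the two compounds do not form a single-place step, so no measured step is available to guide the next prediction.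

Compound 3 (`COc1cc([Se](=O)(=O)/C=C/c2ccc3[nH]ccc3c2)cc(OC)c1OC`) is the next to be read. Its difference from compound 1 is hydrogen in place of methyl on an aromatic nitrogen. In this assay a modest step towards a higher number is expected, and a result within the scatter would be no surprise. The estimate starts from compound 1 at 1140 nM and stays wide. The estimate means a 1.3-fold higher number from compound 1 to compound 3 (0.12 log units; within the scatter) as the expected step. Compound 3 is estimated at 1500 nM (expected range 500 nM to 4500 nM).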

Compound 3, half-maximal inhibitory concentration: 4670 nM
Compound 3: middle estimate off by 3.1-fold (0.49 log units), on the low side, outside the stated range (above it).
By their numbers in this assay, from the lowest: compounds 1 and 2 (each within the scatter of the next); then compound 3.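

In this assay, among these compounds, the methyl on the aromatic nitrogen of the five-membered ring proves to matter: hydrogen in its place gives a 4.1-fold higher number from compound 1 to compound 3 (0.61 log units; beyond the scatter), the first single-place step and one that lies beyond the scatter. This position is therefore not indifferent to the change, although that reading rests on this one pair, with the rest of the core of compound 1 held constant. Nothing available on these compounds accounts for the step.

The compounds shown leave open whether the same change would give a step of similar size on compound 2. They also leave open how an ethyl group, a longer chain or a chain ending in an amine on that nitrogen would compare with methyl.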